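Amide variation at the polar end of the shared core

A few compounds are considered here, and "the series" means these few. Any claim that something is new, unique, unknown or untested is made for them only; others in the source may bear on it.

Measured so far:
compound 1 `CC#C[C@@H](CC(=O)O)c1ccc(OC[C@H]2COc3ccc(CO)cc3O2)cc1`: > 30000 nM
compound 2 `CC#C[C@@H](CC(=O)O)c1ccc(OC[C@H]2COc3ccc(C(=O)N(C)C)cc3O2)cc1`: > 30000 nM

In a functional assay on HEK293 cells for agonist activity at Free fatty acid receptor 1 (Homo sapiens), read by fluorescence and calcium flux, with a stated time of 10 min (a lower number here means that less compound is needed, a higher number that more compound is needed for the effect), compound 1 gives > 30000 nM, which is a limit of the assay and not a number. In the same assay compound 2 gives > 30000 nM, again a limit. Compound 2 therefore stands at the edge of what the assay reports: the limit of > 30000 nM in this assay, at which 2 of the 2 values shown sit. Going by the values given here, the only step between measured compounds, a step that the two limits leave unreadable from compound 1 to compound 2, is unreadable for that reason, so the series gives no sign that this position moves potency in either direction.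

Compound 3 `CC#C[C@@H](CC(=O)O)c1ccc(OC[C@H]2COc3ccc(C(=O)N4CCOCC4)cc3O2)cc1` differs from compound 2 by morpholin-4-yl in place of dimethylamino on a carbonyl carbon. The step from compound 1 to compound 2 is the only one that bears on this change, and it gives no size. No step beyond the scatter is expected in this assay; another limit is the likeliest outcome. Compound 3 is expected near 30000 nM, within 10000 nM to 100000 nM. The estimated step is a number no higher from compound 2 to compound 3 (the limit leaves the size open).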

Compound 3, half-maximal effective concentration: > 50000 nM
Compound 3 gave a limit, no number; the forecaster's own chance of this, stated with the estimate: 85%; middle value at least 1.6-fold (0.22 log units) away from the limit.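

In this assay compound 3 gives > 50000 nM, a limit of the assay and not a number. Going by these compounds alone, no step among compound 1, compound 2 and compound 3 can be read. The compounds shown leave open whether hydroxymethyl, dimethylcarbamoyl or (morpholin-4-yl)carbonyl on an aromatic carbon differ in potency at all.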